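The compounds below may be only part of what the source reports. "The series", "measured", "known", "first", "only" and "open" are said of these compounds alone.

Compound 1 `Fc1ccccc1Cn1cc(CSC(=S)N2CCNCC2)nn1`: 56200 nM
Compound 2 `COc1ccc(Cn2cc(CSC(=S)N3CCNCC3)nn2)cc1`: > 128000 nM
Compound 3 `S=C(SCc1cn(Cc2ccc(Cl)c(Cl)c2)nn1)N1CCNCC1`: "not determined" (no result reported)

In a functional assay on PC-3 cells (Homo sapiens) for inhibition, read by MTT assay, with a stated time of 72 h (on this read-out higher numbers stand for weaker inhibition and lower numbers for stronger inhibition), compound 1 gives 56200 nM. Compound 2 reaches only the limit of the assay, > 128000 nM. For compound 3 the entry reads "not determined" (no result reported), so no result was reported.

Compound 2 thus stands at the limit of > 128000 nM in this assay, at which 1 of the 3 values shown sits, with no single number of its own. Within the data shown here, the one measured step, an at least 2.2-fold higher number from compound 1 to compound 2 (0.35 log units; beyond the scatter), concerns a change at a different place on the shared core and does not bear on the change now considered. Compound 4 `COc1ccc(Cn2cc(CSC(=S)N3CCN(C(=O)OCc4ccccc4)CC3)nn2)cc1` differs from compound 2 by benzyloxycarbonyl in place of hydrogen on an amine nitrogen in a ring. Among the measured compounds shown here, no measured step touches this amine nitrogen in a ring, so no step in this assay can be foreseen beyond the scatter in either direction. Compound 4 is therefore expected to give about 120000 nM, between 30000 nM and 300000 nM, an expected step of an at least 1.0-fold lower number from compound 2 to compound 4 (0.02 log units; that floor lies within the scatter), with a fair chance that only a limit is reported again.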

Compound 4, half-maximal inhibitory concentration: > 128000 nM
Compound 4: only a limit was reported (the forecaster's own chance of this, stated with the estimate: 50%); middle value at least 1.0-fold (0.02 log units) from the limit.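

Compound 2 and compound 4 both reach only a limit in this assay, so no step between them can be read: the limit of > 128000 nM in this assay, at which 2 of the 4 values shown sit.

The compounds shown leave open whether benzyloxycarbonyl in place of hydrogen on this amine nitrogen in a ring changes inhibition at all.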